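From furan-2-yl to 4-methoxyphenyl on the shared core

The source may hold more compounds than are shown below. What is called first, only, known or untested is meant among the compounds shown, and "the series" means these compounds.

For the measured compounds named here, in a functional assay on HT-29 cells (Homo sapiens) for inhibition, with a stated time of 72 h (a higher number here means a weaker inhibitor, a lower number a stronger inhibitor), compound 2 `COc1ccc(S(=O)(=O)N2CCc3cccc(-c4ccco4)c32)cc1` gives 62.5 nM and compound 1 `COc1ccc(S(=O)(=O)N2CCc3cccc(-c4ccc(F)nc4)c32)cc1` gives 109 nM, so these two share the low end of the numbers so far. Compound 3 `COc1ccc(S(=O)(=O)N2CCc3cccc(-c4cc(OC)c(OC)c(OC)c4)c32)cc1`, which also carries a methoxy-bearing ring, stands far higher at 5100 nM. Compound 4 `COc1ccc(-c2cccc3c2N(S(=O)(=O)c2ccc(OC)cc2)CC3)cc1` has 4-methoxyphenyl in place of furan-2-yl on an aromatic carbon. Going by the values given here, the one measured swap of this kind is a 1.7-fold lower number from compound 1 to compound 2 (0.24 log units; within the scatter), a small change. The value of compound 3 at 5100 nM still warns that a clear rise is possible. In this assay the expected change is a 2.4-fold higher number from compound 2 to compound 4 (0.38 log units; beyond the scatter), a modest rise. For compound 4 the estimate is 150 nM, with an expected range from 40 nM to 900 nM.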

Compound 4, half-maximal inhibitory concentration: 277 nM
Compound 4: middle estimate off by 1.8-fold (0.27 log units), on the low side, within the range that was stated.
By their numbers in this assay, from the lowest: compounds 2 and 1 (each within the scatter of the next); then compound 4; then compound 3.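

In this assay the 4-methoxyphenyl group gives the first clear rise among single swaps at this aromatic carbon: a 4.4-fold higher number from compound 2 to compound 4 (0.65 log units; beyond the scatter) and a 2.5-fold higher number from compound 1 to compound 4 (0.41 log units; beyond the scatter). The earlier swap of furan-2-yl for 6-fluoropyridin-3-yl stayed within the scatter, so this position does not accept every aromatic ring equally. Even so, compound 4 at 277 nM has a lower number than compound 3 at 5100 nM. Nothing available explains the rise. Still open, as far as these compounds go, is how a plain phenyl ring, an amine or a carboxylic acid would fare at this position.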